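Aryl for ester on the shared core: expected step

The source may hold more compounds than are shown below. What is called first, only, known or untested is meant among the compounds shown, and "the series" means these compounds.

compound 1 `COC(=O)c1cncc(NS(=O)(=O)c2cc(Cl)ccc2OC)c1`: 65 nM
compound 2 `COc1ccc(C(F)(F)F)cc1S(=O)(=O)Nc1cccnc1`: 183 nM

In an assay on isolated protein for inhibition of alkaline phosphatase, tissue-nonspecific isozyme (Homo sapiens) (a lower number here means a stronger inhibitor, a higher number a weaker inhibitor), compound 1 gives 65 nM, the lowest of the two numbers shown; compound 2 gives 183 nM, a higher number that lies beyond the scatter. Among the compounds with values here, no pair of measured compounds differs in one place only, so no single-change step is known. Compound 3 `COc1ccc(Cl)cc1S(=O)(=O)Nc1cncc(-c2ccc(C)cc2)c1` arises from compound 1 by 4-methylphenyl in place of methoxycarbonyl on an aromatic carbon. The measured pair offers no guide to such an exchange, so the direction is open. For compound 3 the estimate in this assay is 55 nM, range 15 nM to 220 nM. The expected step is a 1.2-fold lower number from compound 1 to compound 3 (0.07 log units; within the scatter), within the scatter.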

Compound 3, half-maximal inhibitory concentration: 147 nM
The estimate for compound 3 lay 2.7-fold (0.43 log units) below the measured number; measured number inside the range.
By their numbers in this assay, from the lowest: compound 1; then compounds 3 and 2 (each within the scatter of the next).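

On the shared core, in this assay, 4-methylphenyl in place of methoxycarbonyl on an aromatic carbon two atoms from the ring nitrogen gives a 2.3-fold higher number from compound 1 to compound 3 (0.35 log units; beyond the scatter) and so costs only modestly. This position therefore tolerates a change from an ester with two hydrogen-bond acceptors to a larger carbon-only aromatic ring, though the ester holds the lower number. No measurement at hand bears on the reason for this step.

Going by these compounds, whether the step follows from losing the ester or from adding the aryl ring stays open. A carboxylic acid, a primary amide or an unsubstituted phenyl at this position would help to separate the two.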